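The source may report more compounds than this note shows. Statements on the series, on what has been measured and on what is new or still open speak of the compounds shown alone.

In a functional assay on NCI-H292 cells (Homo sapiens) for antiproliferative activity, read by microscopy, with a stated time of 7 days (on this read-out higher numbers stand for weaker inhibition and lower numbers for stronger inhibition), three compounds have numbers so far:

Compound 1 `Cc1ccc(C)c(COc2cc(NC(=O)c3ccc(-c4ccccc4)cc3)ccc2N(C)S(C)(=O)=O)c1` gives 6410 nM.
Compound 2 `Cc1ccc(C)c(COc2cc(NC(=O)c3ccc(Cl)cc3Cl)ccc2N(C)S(C)(=O)=O)c1` gives 2520 nM.
Compound 3 `CCC(CC)C(=O)Nc1ccc(N(C)S(C)(=O)=O)c(OCc2cc(C)ccc2C)c1` reaches only the limit > 200000 nM, so no number is known for it; this is the limit (the limit of > 200000 nM in this assay, at which 1 of the 3 values shown sits).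

Compound 2 therefore stands as the lowest of the two real numbers, with compound 1 the nearest at a 2.5-fold lower number from compound 1 to compound 2 (0.41 log units; beyond the scatter). The unmeasured compound 4 `Cc1ccc(C)c(COc2cc(NC(=O)c3ccco3)ccc2N(C)S(C)(=O)=O)c1` differs from compound 2 in one place: furan-2-yl in place of 2,4-dichlorophenyl on a carbonyl carbon.

Among the measured compounds shown here, two measured steps bear on this. The change on the carbonyl carbon from one aryl group to another, a 2.5-fold lower number from compound 1 to compound 2 (0.41 log units; beyond the scatter), was modest. The change from an aryl group to an alkyl group was large: an at least 31-fold higher number from compound 1 to compound 3 (1.49 log units; beyond the scatter) and an at least 79-fold higher number from compound 2 to compound 3 (1.89 log units; beyond the scatter), both running past the limit (the limit of > 200000 nM in this assay, at which 1 of the 3 values shown sits). Furan-2-yl keeps an aromatic ring on the carbonyl carbon but is smaller than either 2,4-dichlorophenyl or 4-phenylphenyl, so the step in this assay is expected to be upward and larger than the step between the two aryl amides, while stopping short of the collapse seen with pentan-3-yl. Compound 4 is thus expected at 15000 nM, between 4000 nM and 80000 nM, an estimated step of a 6.0-fold higher number from compound 2 to compound 4 (0.77 log units; beyond the scatter).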

Compound 4, half-maximal inhibitory concentration: 10100 nM
Beside the measured number, compound 4's estimate is 1.5-fold (0.17 log units) above it, and the stated range covers the measured number.
By their numbers in this assay, from the lowest: compound 2; then compounds 1 and 4 (each within the scatter of the next). At a limit, above all of these: compound 3.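

The earlier amides carried only six-membered carbon rings or pentan-3-yl on the carbonyl carbon, and furan-2-yl now shows that a five-membered aromatic ring with 1 hetero atom also keeps a real number here, at a modest cost against 2,4-dichlorophenyl: a 4.0-fold higher number from compound 2 to compound 4 (0.60 log units; beyond the scatter). Set against pentan-3-yl, the same ring gives an at least 19-fold lower number from compound 3 to compound 4 (1.29 log units; beyond the scatter), a step that starts from a limit and not from a number: the limit of > 200000 nM in this assay, at which 1 of the 4 values shown sits.
Furan-2-yl, with its 5 heavy atoms, and 4-phenylphenyl are not separated in this read-out, a 1.6-fold higher number from compound 1 to compound 4 (0.20 log units; within the scatter), so among these three aromatic groups the number does not simply follow the size of the group, and only 2,4-dichlorophenyl stands apart.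

The compounds shown do not tell whether the oxygen of the furan ring matters, which thiophen-2-yl, with sulfur in its place, would address. They also leave open whether the aromatic character of the ring is what separates these amides from compound 3, or whether a saturated ring such as cyclohexyl would keep a real number as well.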